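The source may hold more compounds than are shown below. What is called first, only, known or untested is meant among the compounds shown, and "the series" means these compounds.

Compound 1 `CCOc1cc(C(=O)Nc2nn[nH]n2)nc(-c2ccc(C)cc2)c1`: in a functional assay on the whole organism with Rattus norvegicus as the target, at a dose of 1 mg/kg by the oral route (on this read-out higher numbers stand for a stronger effect at the one dose given and lower numbers for a weaker effect), compound 1 gives 65%.
Compound 2 `CCOc1cc(C(=O)Nc2nn[nH]n2)nc(-c2ccc(N)cc2)c1`: compound 2 gives 52%.

Compound 2 stands lowest of the two numbers; its nearest neighbour is compound 1, and the step of a number 13 percentage points lower from compound 1 to compound 2 (beyond the scatter) goes with an amino in place of methyl on an aromatic carbon. Compound 3 `CCCCc1cc(C(=O)Nc2nn[nH]n2)nc(-c2ccc(N)cc2)c1` differs from compound 2 by butyl in place of ethoxy on an aromatic carbon. Within the data shown here, no measured step changes this position, and the only known step concerns another group, so nothing points to a shift beyond the scatter. Compound 3 is therefore expected to give about 50%, between 30% and 70%, a step of a number 2 percentage points lower from compound 2 to compound 3 (within the scatter).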

Compound 3, a percentage reported as inhibition, in the whole organism at one dose (the size of the read-out at that dose, not a potency): 81%
For compound 3 the middle estimate is 31 percentage points below the measured one; measured number outside the range, above it.
By their numbers in this assay, from the lowest: compound 2; then compound 1; then compound 3.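

In this assay, the position opposite the ring nitrogen proves sensitive to change: butyl in place of ethoxy gives a number 29 percentage points higher from compound 2 to compound 3 (beyond the scatter). Among these compounds, the only earlier step lay elsewhere, at the 4-aminophenyl group, so this is the first sign that the ethoxy oxygen is not needed for the effect at this dose. Nothing measured here accounts for the rise. The compounds shown leave open whether a longer chain such as hexyl, or an amine at this position, would go further, and whether butyl would give a similar step alongside the methyl group of compound 1.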